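This account rests on a few compounds, and the source may have more. Where it says the series, first, only, none or still open, it means among the compounds named here.

Among the compounds with values here, compound 2, with the structure `CCc1cc2c(C(=O)c3cc(Br)c(O)c(Br)c3)c(OC)ccc2o1`, is the only member of this small set that carries a number in an assay for inhibition of solute carrier family 22 member 12 (Homo sapiens), read by scintillation counting, with a stated time of 60 min; on this read-out lower numbers stand for stronger inhibition and higher numbers for weaker inhibition. In this assay compound 2 gives 358 nM. Compound 1, with the structure `CCc1oc2c(OC)cccc2c1C(=O)c1ccc(OC)cc1`, belongs to the same series, but in this assay compound 1 is recorded as "not determined" (no result reported), so nothing can be said about where it stands relative to compound 2. The next member, compound 3, has the structure `CCc1cc2c(C(=O)c3cc(Br)c(O)c(Br)c3)c(O)ccc2o1` and is still to be measured in this assay. It differs from compound 2 by a single change, namely (hydrogen in place of methyl on an oxygen on an aromatic ring); the methoxy group on the shared core becomes a hydroxy group, while the dibromo-hydroxyphenyl ketone and the ethyl group remain untouched. Within the data shown here, with no measured pair of this kind available, the size of the step cannot be read from the data, and the account expects a move from compound 2 to compound 3 that stays within or only slightly beyond the scatter, leaning toward a somewhat lower value. For compound 3 the estimated result in this assay is 250 nM, within a range from 80 nM to 800 nM, which corresponds to an expected step of a 1.4-fold lower number from compound 2 to compound 3 (0.16 log units; within the scatter).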

Compound 3, half-maximal inhibitory concentration: 83 nM
Compound 3: the middle estimate sits 3.0-fold (0.48 log units) above what was measured, within the range that was stated.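

In this assay, within the data shown here, the place on an oxygen on an aromatic ring of the shared core proves sensitive to what it carries: hydrogen in place of methyl there brings a 4.3-fold lower number from compound 2 to compound 3 (0.63 log units; beyond the scatter), the first step in this set that can be read at all. The methyl is therefore not required for inhibition at the level of compound 2, and in this one pair methoxy to hydroxy moves the read-out toward stronger inhibition, with the dibromo-hydroxyphenyl ketone and the ethyl group left unchanged. Nothing available accounts for the size of this step, and a single pair gives one observation rather than a rule.

The compounds shown leave open how far this place tolerates anything other than hydrogen or methyl, for instance a longer chain such as ethoxy on the same oxygen, or an amine standing where the hydroxy group stands in compound 3. They also leave open whether the same change would give a step of similar size if the ethyl group or the dibromo-hydroxyphenyl ketone were replaced, for example by a carboxylic acid in place of the ketone.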